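Swapping methoxycarbonyl for methoxy at an assay limit

The source may hold more compounds than are shown below. What is called first, only, known or untested is meant among the compounds shown, and "the series" means these compounds.

- compound 1 `COc1ccc2c(OCCn3c(=O)oc4cc(C)ccc43)ccnc2c1`: > 500 nM, a limit and not a number
- compound 2 `COC(=O)c1ccc2c(c1)oc(=O)n2CCOc1ccnc2cc(OC)ccc12`: > 500 nM, a limit and not a number

Both values come from a functional assay on EBC-1 cells (Homo sapiens) for inhibition, read by sulforhodamine B assay, with a stated time of 72 h; on this read-out higher numbers stand for weaker inhibition and lower numbers for stronger inhibition. Compound 2 stands at the limit of > 500 nM in this assay, at which 2 of the 2 values shown sit.

Compound 3 `COc1ccc2c(OCCn3c(=O)oc4cc(OC)ccc43)ccnc2c1` has methoxy in place of methoxycarbonyl on an aromatic carbon. Among the measured compounds shown here, one measured step bears on this change, since it also involves methoxycarbonyl on an aromatic carbon. That step, a step that the two limits leave unreadable from compound 1 to compound 2, has no size that can be carried over. With no size to build on, no step beyond the usual scatter is expected in this assay, and no direction can be given. The estimated change is a step that the limit leaves unreadable from compound 2 to compound 3. For compound 3, the expected value is 800 nM, with an estimated range from 200 nM to 3000 nM.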

Compound 3, half-maximal inhibitory concentration: > 500 nM
Compound 3 ended at the assay's limit (the forecaster's own chance of this, stated with the estimate: 70%); the middle value does not contradict the limit.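

Compound 1, compound 2 and compound 3 all end at a limit and not a number, so no step among them can be read: the limit of > 500 nM in this assay, at which 3 of the 3 values shown sit.

Open remains how strongly each compound inhibits, and whether methyl, methoxycarbonyl or methoxy on that aromatic carbon makes any difference.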